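Swapping the aryl ether of a coumarin imine

This account rests on a few compounds, and the source may have more. Where it says the series, first, only, none or still open, it means among the compounds named here.

Compound 3 `Cc1nn(C)c(Oc2ccccc2F)c1/C=N\CCCCCCOc1cc2oc(=O)cc(C)c2cc1Cl` was tested in a functional assay on SMMC-7721 cells (Homo sapiens) for antiproliferative activity, read by MTT assay, with a stated time of 72 h (on this read-out lower numbers stand for stronger inhibition and higher numbers for weaker inhibition), and gives > 25000 nM, which is a limit of the assay rather than a number. This is the limit of > 25000 nM in this assay, at which 1 of the 3 values shown sits. Compound 1 `Cc1nn(C)c(Oc2ccc(F)cc2)c1/C=N\CCCCCOc1cc2oc(=O)cc(C)c2cc1Cl` gives 22100 nM, and compound 2 `Cc1ccc(Oc2c(/C=N\CCCCCOc3cc4oc(=O)cc(C)c4cc3Cl)c(C)nn2C)cc1` gives 11100 nM; the step of a 2.0-fold lower number from compound 1 to compound 2 (0.30 log units; within the scatter) concerns a change on the aryl ether, though not the change made here. Compound 4 `Cc1nn(C)c(Oc2cccc(Cl)c2)c1/C=N\CCCCCCOc1cc2oc(=O)cc(C)c2cc1Cl` carries 3-chlorophenyl in place of 2-fluorophenyl on an oxygen on an aromatic ring. Among the compounds with values here, no measured step covers an exchange of fluorine for chlorine on that ring, and the only aryl step available stayed within the scatter, so no step beyond the scatter is expected. The step of an at least 1.1-fold lower number from compound 3 to compound 4 (0.05 log units; that floor lies within the scatter) is estimated to remain within the scatter. Compound 4 is therefore expected to give 22000 nM, between 8000 nM and 60000 nM.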

Compound 4, half-maximal inhibitory concentration: 5260 nM
Compound 4: the middle estimate sits 4.2-fold (0.62 log units) above what was measured; measured number below the stated range.
By their numbers in this assay, from the lowest: compound 4; then compounds 2 and 1 (each within the scatter of the next). At a limit, above all of these: compound 3.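

In this assay, 3-chlorophenyl in place of 2-fluorophenyl on an oxygen on an aromatic ring gives an at least 4.7-fold lower number from compound 3 to compound 4 (0.67 log units; beyond the scatter). The aryl ether is thus a place where a single exchange can move the number beyond the scatter, which the earlier step on that ring did not show. Compound 3 stands at a limit of the assay rather than at a number, so the size of this step is only a floor: the limit of > 25000 nM in this assay, at which 1 of the 4 values shown sits.

The step changes both the halogen and where it sits on the ring, and the compounds shown do not separate the two. From the compounds shown here alone, how a methoxy group or an amine on that ring would read also stays open.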